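The source may hold more compounds than are shown below. What is called first, only, known or untested is meant among the compounds shown, and "the series" means these compounds.

Three compounds measured in an ADME assay on HepG2 cells (Homo sapiens) for cytotoxicity, read by luminescence, CellTiter-Glo and ATP content, with a stated time of 72 h (on this read-out lower numbers stand for an effect already at smaller amounts and higher numbers for an effect only at larger amounts of compound), set the scene. Compound 1 `COc1ccc(F)cc1CNCCCNc1ccnc2cc(Cc3cc(C)cc(C)c3)ccc12` gives 940 nM in this assay. Compound 2 `CCC(CC)c1ccc2c(NCCCNCc3cccc(OC)c3O)ccnc2c1` gives 410 nM, and compound 3 `COc1cccc(CNCCCNc2ccnc3cc(Oc4ccccc4)ccc23)c1O` gives 6800 nM. Compound 1 therefore stands second highest of the three, with compound 2 its nearest neighbour and compound 3 furthest away.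

The new compound 4 `COc1ccc(F)cc1CNCCCNc1ccnc2cc(-c3ccccc3)ccc12` differs from compound 1 in one place: phenyl in place of 3,5-dimethylbenzyl on an aromatic carbon. The group that leaves is the larger one, and the group that enters is a plain phenyl sitting directly on the aromatic carbon of the shared core.

Within the data shown here, only one measured step bears on this part of the molecule. Swapping a pentan-3-yl group for a phenoxy group on an aromatic carbon of the core gave a 17-fold higher number from compound 2 to compound 3 (1.22 log units; beyond the scatter). That is a change of a different kind, since an oxygen-linked ring enters rather than a bare ring, so it is a rough guide only. It suggests that altering the group at this position can move the number upward by a large margin, whereas shrinking a benzyl to a phenyl seems a gentler change.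

A modest rise is therefore expected, a 1.7-fold higher number from compound 1 to compound 4 (0.23 log units; within the scatter), and compound 4 is estimated at 1600 nM, within a range from 500 nM to 5000 nM.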

Compound 4, half-maximal effective concentration: 2960 nM
Estimate against measurement, compound 4: 1.9-fold (0.27 log units) below; low and high end bracket the measured number.
By their numbers in this assay, from the lowest: compound 2; then compound 1; then compound 4; then compound 3.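

In this assay the swap of 3,5-dimethylbenzyl for phenyl on this aromatic carbon gives a 3.1-fold higher number from compound 1 to compound 4 (0.50 log units; beyond the scatter) and so shows that exchanging one carbon-only aromatic group for another, with no hydrogen-bond donors or acceptors on either side, can move the number beyond the usual scatter. Among these compounds, the only earlier step at this place was a 17-fold higher number from compound 2 to compound 3 (1.22 log units; beyond the scatter) on compounds with a different group on the side chain; the new step points the same way and is the smaller of the two, so two different replacements, on two different side chains, have now both raised the number. No measurement at hand speaks to what lies behind this rise.

The compounds shown leave open whether the step belongs to the two methyl groups or to the carbon linking the ring to the shared core, a question that an unsubstituted benzyl group on the same core would help to settle. They also leave open how the number would respond to a group of a different kind at this carbon, such as an amine or a carboxylic acid.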